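Selenocyanate aryl carbamates: chloro for fluoro

The compounds below may be only part of what the source reports. "The series", "measured", "known", "first", "only" and "open" are said of these compounds alone.

Measured so far:
compound 1 `N#C[Se]c1ccc(NC(=O)Oc2ccc(F)cc2)cc1`, > 25%
compound 2 `C=CCOC(=O)Nc1ccc([Se][Se]c2ccc(NC(=O)OCC=C)cc2)cc1`, 10.9%

In a physicochemical assay, with a stated time of 6 min, tested at 0.1 mg/mL (a higher number here means more inhibition at the concentration tested (going by the name of the read-out), a lower number less inhibition), compound 1 gives > 25%, which is a limit of the assay and not a number. Compound 2 gives 10.9% in this assay. For compound 1 only a limit is known, (the limit of > 25% in this assay, at which 1 of the 2 values shown sits).

Compound 3 `N#C[Se]c1ccc(NC(=O)Oc2ccc(Cl)cc2)cc1` differs from compound 1 in one place: chloro in place of fluoro on an aromatic carbon. Among the compounds with values here, no step between measured compounds bears on this change, so in this assay compound 3 is expected to sit close to compound 1, with the step that the limit leaves unreadable from compound 1 to compound 3 expected not to go beyond the scatter. Compound 3 is expected to give 35% in this assay, within 20% to 60%.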

Compound 3, a percentage reported as inhibition, at one concentration (the size of the read-out at that concentration, not a potency): > 25%
Compound 3 was reported as a limit; the forecaster's own chance of this, stated with the estimate: 40%; the middle value is on the limit's open side.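

Compound 1 and compound 3 both sit at a limit in this assay, so no step can be read for chloro in place of fluoro: the limit of > 25% in this assay, at which 2 of the 3 values shown sit.

The compounds shown leave open whether compound 1 and compound 3 differ at all in this assay.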